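Aryl sulfamate amides: exchanging the amino substituent on the benzoyl ring

The source may report more compounds than this note shows. Statements on the series, on what has been measured and on what is new or still open speak of the compounds shown alone.

The series shares an aryl sulfamate core carrying an amide-linked phenyl ring that bears a tertiary amino group. In an assay on HEK293 cells for inhibition of Steryl-sulfatase (Homo sapiens), tested at 1 uM (a lower number here means a weaker effect, a higher number a stronger effect of the compound at the concentration tested), compound 2 `CC(C)CCN(CCC(C)C)c1ccc(C(=O)N2CCc3ccc(OS(N)(=O)=O)cc3C2)cc1` gives 90.8% and stands highest of the three measured values. Compound 1 `NS(=O)(=O)Oc1ccc2c(c1)CN(C(=O)c1ccc(N3CCC(N4CCCCC4)CC3)cc1)CC2` gives 53.7%, a number lower than that of compound 2 and beyond the scatter. Compound 3 `CN(C)CCN(CCN(C)C)c1cccc(C(=O)N2CCc3ccc(OS(N)(=O)=O)cc3C2)c1` gives 17.1%, the lowest of the set and again beyond the scatter relative to compound 2.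

Compound 4 `CN(CCCN1CCCCC1)c1ccc(C(=O)N2CCc3ccc(OS(N)(=O)=O)cc3C2)cc1` has not yet been measured. It differs from compound 2 in one place: methyl(3-(piperidin-1-yl)propyl)amino in place of diisopentylamino on an aromatic carbon. Going by the values given here, no step between measured compounds matches this change exactly, so its size is a guess. Both compounds that carry an amino-bearing side chain with a second nitrogen, compound 1 with 53.7% and compound 3 with 17.1%, sit well under compound 2, which suggests a downward step for compound 4 in this assay, beyond the scatter. The estimated step from compound 2 to compound 4 is a number 35.8 percentage points lower from compound 2 to compound 4 (beyond the scatter), expected to be a clear loss. Compound 4 is therefore estimated at 55% in this assay, with a range from 30% to 80%.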

Compound 4, a percentage reported as inhibition, at one concentration (the size of the read-out at that concentration, not a potency): 40.7%
The estimate for compound 4 lay 14.3 percentage points above the measured number, within the range that was stated.
By their numbers in this assay, from the lowest: compound 3; then compound 4; then compound 1; then compound 2.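

In this assay, going by these compounds alone, the exchange of diisopentylamino for methyl(3-(piperidin-1-yl)propyl)amino, on an aromatic carbon para to a large group, gives the first reading of a change made in one place: a number 50.1 percentage points lower from compound 2 to compound 4 (beyond the scatter). The position therefore does not accept every amino substituent of this size, since both groups have the same heavy-atom count and the loss appears with no change in that count. The differences that remain are a six-membered non-aromatic ring and a second nitrogen in the entering group, and no available data indicate which of these, if either, accounts for the loss.

Going by these compounds, the role of the second nitrogen remains open, and a cyclohexyl group in place of the piperidine at the end of the same propyl chain would separate that nitrogen from the ring. Also open, on these data alone, is how the result depends on the terminal group and the chain that carries it, which a morpholine at the chain end or a butyl chain between the two nitrogens would test.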